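The source may hold more compounds than are shown below. What is called first, only, known or untested is meant among the compounds shown, and "the series" means these compounds.

In an ADME assay on microsomes (Mus musculus) for metabolic stability (a lower number here means slower removal, a higher number faster removal of the compound), compound 3 (`Cc1cc(C(F)(F)F)c2cccc(OCc3c(Cl)ccc(S(=O)(=O)N4CCCCC4)c3Cl)c2n1`) gives 1000 mL/min/kg and compound 2 (`Cc1cc(C(F)(F)F)c2cccc(OCc3c(Cl)ccc(S(=O)(=O)N4CC[C@@H](N(C)C)C4)c3Cl)c2n1`) gives 867 mL/min/kg, while compound 1 (`Cc1cc(C(F)(F)F)c2cccc(OCc3c(Cl)ccc(S(=O)(=O)N4CCC[C@H]4C(=O)O)c3Cl)c2n1`) gives 13.3 mL/min/kg. Compound 4 (`Cc1cc(C(F)(F)F)c2cccc(OCc3c(Cl)ccc(S(=O)(=O)N4C[C@@H](C)O[C@@H](C)C4)c3Cl)c2n1`) differs from compound 3 as follows: 2,6-dimethylmorpholin-4-yl in place of piperidin-1-yl on a sulfonyl sulfur. That places 2,6-dimethylmorpholin-4-yl in place of piperidin-1-yl on a sulfonyl sulfur. Going by the values given here, three measured steps touch this same place. The two large ones, a 65-fold higher number from compound 1 to compound 2 (1.81 log units; beyond the scatter) and a 75-fold higher number from compound 1 to compound 3 (1.88 log units; beyond the scatter), both start from the 2-carboxypyrrolidin-1-yl group, which compound 4 lacks. The step without that group, a 1.2-fold higher number from compound 2 to compound 3 (0.06 log units; within the scatter), stays within the scatter. No step beyond the scatter is therefore expected in this assay, and the estimated change is a 1.7-fold lower number from compound 3 to compound 4 (0.22 log units; within the scatter). For compound 4 the expected value is 600 mL/min/kg, with an estimated range of 250 mL/min/kg to 1100 mL/min/kg.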

Compound 4, clearance: 933 mL/min/kg
Beside the measured number, compound 4's estimate is 1.6-fold (0.19 log units) below it; the measured number falls inside the stated range.
By their numbers in this assay, from the lowest: compound 1; then compounds 2, 4 and 3 (each within the scatter of the next).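

In this assay the change from piperidin-1-yl to 2,6-dimethylmorpholin-4-yl on the sulfonyl sulfur leaves the number in place, with a 1.1-fold lower number from compound 3 to compound 4 (0.03 log units; within the scatter) and a 1.1-fold higher number from compound 2 to compound 4 (0.03 log units; within the scatter) both within the scatter. Among the groups shown, only 2-carboxypyrrolidin-1-yl stands apart, with a 70-fold higher number from compound 1 to compound 4 (1.85 log units; beyond the scatter) as the step to the new group. Nothing at hand explains this grouping.

As far as these compounds go, it remains open whether a carboxylic acid carried on the piperidin-1-yl or 2,6-dimethylmorpholin-4-yl ring would give a similarly low number. From the compounds shown here alone, it is also open whether an amide in place of that acid would do so.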